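Lengthening the acyl hydrazide chain on two aryl cores

A few compounds are considered here, and "the series" means these few. Any claim that something is new, unique, unknown or untested is made for them only; others in the source may bear on it.

Measured compounds:
- Compound 1, `CCC(=O)NNC(=O)c1csc2ncc(-c3ccc(C)cc3)n12`, gives 18500 nM in a functional assay on PC-3 cells (Homo sapiens) for antiproliferative activity, read by MTT assay, with a stated time of 72 h; a lower number here means a stronger inhibitor, a higher number a weaker inhibitor.
- Compound 2, `CCCC(=O)NNC(=O)c1csc2ncc(-c3ccc(C)cc3)n12`, gives 53500 nM in this assay.
- Compound 3, `CC(=O)NNC(=O)c1csc2ncc(-c3ccc(Br)cc3)n12`, gives 12700 nM in this assay.

All three compounds share a hydrazide-linked bicyclic core carrying an aryl ring; compound 1 and compound 2 carry one aryl group, compound 3 another, and the difference between the two cores is not broken down here. Compound 4, `CCC(=O)NNC(=O)c1csc2ncc(-c3ccc(Br)cc3)n12`, has not yet been measured. It differs from compound 3 by methyl in place of hydrogen on a saturated chain carbon bound to a carbonyl carbon.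

A change of the same kind, though not the same, is already measured: compound 2 differs from compound 1 by methyl in place of hydrogen on a saturated chain carbon, two bonds along the chain from a carbonyl carbon, one chain carbon further from the carbonyl than in the new pair. That step gave a 2.9-fold higher number from compound 1 to compound 2 (0.46 log units; beyond the scatter), a weakening that lies beyond the scatter.

Compound 3 shows the lowest number of the three, though its gap to compound 1 is within the scatter, while its gap to compound 2 is beyond it. Since compound 1 already carries the propanoyl group that compound 4 gains, and since the measured lengthening weakened compound 2 relative to compound 1 by a 2.9-fold higher number from compound 1 to compound 2 (0.46 log units; beyond the scatter), compound 4 is expected to come out somewhat weaker than compound 3, by roughly a 1.6-fold higher number from compound 3 to compound 4 (0.20 log units; within the scatter). The expected value for compound 4 is 20000 nM, in a range estimated from 9000 nM to 45000 nM.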

Compound 4, half-maximal inhibitory concentration: 43700 nM
Compound 4: the middle estimate sits 2.2-fold (0.34 log units) below what was measured, and the stated range covers the measured number.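

In this assay, going from acetyl to propanoyl on the bromo-bearing core gives a 3.4-fold higher number from compound 3 to compound 4 (0.54 log units; beyond the scatter), so here the added methyl goes with a weaker compound. Set beside the earlier lengthening on the methyl-bearing core, the step carries over in both direction and size: the same change on two cores in this assay, a 2.9-fold higher number (0.46 log units; beyond the scatter) from compound 1 to compound 2 and a 3.4-fold higher number (0.54 log units; beyond the scatter) from compound 3 to compound 4, 1.2-fold (0.08 log units) apart, within the scatter of two such steps. Among the compounds shown here, this agreement rests on only two steps that are not identical, since the added methyl sits one chain carbon further from the carbonyl in compound 2 than in compound 4, so it sets no rule for other cores and gives no cause for the weakening; moreover, with the propanoyl chain held fixed, bromo in place of methyl gives a 2.4-fold higher number from compound 1 to compound 4 (0.37 log units; beyond the scatter), so a matching chain step does not mean that the two cores reach the same level of activity.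

The compounds shown leave open whether a butanoyl or longer chain on the bromo-bearing core would weaken activity further, and how acetyl would behave on the methyl-bearing core. They also say nothing about a branched chain, or about a chain carrying an amine or a carboxylic acid.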